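The source may report more compounds than this note shows. Statements on the series, on what has been measured and on what is new or still open speak of the compounds shown alone.

The measured compounds:
Compound 1 `CCOC(=O)c1cnc(-c2cccs2)nc1NN1C(=O)C=C(C)C1=O` gives 20 nM in a functional assay on Jurkat cells for inhibition of nuclear factor NF-kappa-B complex (Homo sapiens); a lower number here means a stronger inhibitor, a higher number a weaker inhibitor.
Compound 2 `CCOC(=O)c1cnc(-c2ccc(C)s2)nc1NN1C(=O)C=C(C)C1=O` gives 200 nM in this assay.
Compound 3 `CCOC(=O)c1cnc(-c2cc3ccccc3s2)nc1NN1C(=O)C=C(C)C1=O` gives 4000 nM in this assay.

Compound 1 holds the lowest number of the three, with compound 2 nearest to it and compound 3 furthest away. Compound 4 `CCOC(=O)c1cnc(S(=O)(=O)c2ccccc2)nc1NN1C(=O)C=C(C)C1=O` has not yet been measured. It differs from compound 1 in one place: phenylsulfonyl in place of thiophen-2-yl on an aromatic carbon. Both measured steps touch the same part of the shared core and so bear on this change. a 10-fold higher number from compound 1 to compound 2 (1.00 log units; beyond the scatter) shows that even methyl in place of hydrogen on the thiophen-2-yl group raises the number, and a 200-fold higher number from compound 1 to compound 3 (2.30 log units; beyond the scatter) shows that 1-benzothiophen-2-yl in place of thiophen-2-yl raises it far more. Phenylsulfonyl is a further departure from thiophen-2-yl than either of those, so a large rise in the number is expected in this assay. The expected step is a 150-fold higher number from compound 1 to compound 4 (2.18 log units; beyond the scatter). Compound 4 is therefore estimated at 3000 nM, with a likely range from 500 nM to 20000 nM.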

Compound 4, half-maximal inhibitory concentration: 10000 nM
The estimate for compound 4 lay 3.3-fold (0.52 log units) below the measured number, within the range that was stated.
By their numbers in this assay, from the lowest: compound 1; then compound 2; then compound 3; then compound 4.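

The earlier compounds shown here varied only thiophene-based groups at this position, whereas compound 4 carries phenylsulfonyl on the aromatic carbon between two ring nitrogen atoms and has the highest number of the set, with a 500-fold higher number from compound 1 to compound 4 (2.70 log units; beyond the scatter) and a 50-fold higher number from compound 2 to compound 4 (1.70 log units; beyond the scatter). Even against 1-benzothiophen-2-yl, the group with the highest number among the earlier compounds, the step in this assay is a 2.5-fold higher number from compound 3 to compound 4 (0.40 log units; beyond the scatter), so all three replacements of thiophen-2-yl shown raise the number. Nothing available explains this rise.

From the compounds shown here alone, whether the rise belongs to the sulfonyl part or to the phenyl ring stays open, and a plain phenyl or a methylsulfonyl group at this position would separate the two. Also open, going by these compounds, is how an amine such as morpholine or a small ethoxy group would behave here.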